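A Five-Membered Ring in Place of Phenyl: Expected Binding

The compounds below may be only part of what the source reports. "The series", "measured", "known", "first", "only" and "open" are said of these compounds alone.

Measured compounds:
compound 1, `O=C(O)Cc1sc(C(c2ccc(F)cc2)c2ccc(F)cc2)nc1-c1cc(F)cc(F)c1`: 35 nM
compound 2, `O=C(O)Cc1sc(C(c2ccc(F)cc2)c2ccc(F)cc2)nc1-c1ccnc(F)c1`: 0.48 nM
compound 3, `O=C(O)Cc1sc(C(c2ccc(F)cc2)c2ccc(F)cc2)nc1-c1ccccc1`: 16 nM

All three share one core and differ only in the aromatic group on one carbon of that core. In an in vitro assay on HEK385-7 cells for displacement of a labelled ligand from prostaglandin D2 receptor 2 (Homo sapiens) (a higher number here means a weaker inhibitor, a lower number a stronger inhibitor), compound 3 gives 16 nM, the second highest of the three numbers: it stands close to compound 1, with a 2.2-fold lower number from compound 1 to compound 3 (0.34 log units; beyond the scatter), and far from compound 2, with a 33-fold higher number from compound 2 to compound 3 (1.52 log units; beyond the scatter).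

Compound 4, `O=C(O)Cc1sc(C(c2ccc(F)cc2)c2ccc(F)cc2)nc1-c1ccoc1`, has not yet been measured. It differs from compound 3 in one place: furan-3-yl in place of phenyl on an aromatic carbon

For the measured compounds named here, two measured steps bear on this position. Exchanging one six-membered carbon ring for another, as in the step from compound 1 to compound 3, moved the number only modestly. Bringing a ring hetero atom into this position, as in compound 2, changed the number greatly in this assay, seen in a 33-fold higher number from compound 2 to compound 3 (1.52 log units; beyond the scatter). Going by the values given here, compound 4 also carries a ring hetero atom here, but in a five-membered ring with oxygen, for which no measured step exists, so the expectation is uncertain.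

A moderate step toward a lower number, a 2.0-fold lower number from compound 3 to compound 4 (0.30 log units; within the scatter), is expected for compound 4. The estimated value of compound 4 is 8 nM, in the range 1.5 nM to 45 nM.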

Compound 4, half-maximal inhibitory concentration: 14 nM
Beside the measured number, compound 4's estimate is 1.8-fold (0.24 log units) below it; low and high end bracket the measured number.
By their numbers in this assay, from the lowest: compound 2; then compounds 4 and 3 (each within the scatter of the next); then compound 1.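

In this assay, furan-3-yl in place of phenyl gives a 1.1-fold lower number from compound 3 to compound 4 (0.06 log units; within the scatter), so the smaller five-membered ring with its oxygen cannot be told apart from phenyl at this position. A ring hetero atom in the group on this carbon is therefore not enough on its own to give a number as low as that of compound 2, as there is a 29-fold higher number from compound 2 to compound 4 (1.46 log units; beyond the scatter) when furan-3-yl replaces 2-fluoropyridin-4-yl. Compound 4 also shows a 2.5-fold lower number from compound 1 to compound 4 (0.40 log units; beyond the scatter), a modest gap of the same kind that separates the 3,5-difluorophenyl compound from the phenyl compound, so among compounds 1, 3 and 4 the number stays within a narrow band while compound 2 alone stands far lower.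

A plain pyridin-4-yl group without its fluorine, or a 2-fluorophenyl group without the ring nitrogen, would help show whether the low number of compound 2 depends on the nitrogen, the fluorine or both together. The data shown give no explanation for the large gap between the 2-fluoropyridin-4-yl and furan-3-yl groups.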